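Adding pyridin-2-yl to compound 2

This account rests on a few compounds, and the source may have more. Where it says the series, first, only, none or still open, it means among the compounds named here.

- compound 1 `COc1ccccc1OCC1SCCN1C(=O)CC(C)=O`: 26 mg/kg
- compound 2 `CNC(=O)CC(=O)N1CCSC1COc1ccccc1OC`: 22 mg/kg

In a functional assay on the whole organism (trachea) for inhibition, with Cavia porcellus as the target (on this read-out lower numbers stand for an effect already at smaller amounts and higher numbers for an effect only at larger amounts of compound), compound 1 gives 26 mg/kg and compound 2 gives 22 mg/kg, so the two lie within the scatter of each other. Compound 3 `COc1ccccc1OCC1SCCN1C(=O)CC(=O)NCc1ccccn1` has pyridin-2-yl in place of hydrogen on a saturated chain carbon bound to an amide-type nitrogen. For the measured compounds named here, the only measured step is a 1.2-fold lower number from compound 1 to compound 2 (0.07 log units; within the scatter), which stays within the scatter. Going by the values given here, it involves a different change, so it offers only a weak guide, and no measured step adds pyridin-2-yl. No change beyond the scatter is therefore expected in this assay. The estimated step is a 1.1-fold lower number from compound 2 to compound 3 (0.04 log units; within the scatter). Compound 3 is expected at 20 mg/kg, with an estimated range of 7 mg/kg to 55 mg/kg.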

Compound 3, dose for half-maximal effect: 64 mg/kg
Compound 3: middle estimate off by 3.2-fold (0.51 log units), on the low side, outside the stated range (above it).
By their numbers in this assay, from the lowest: compounds 2 and 1 (each within the scatter of the next); then compound 3.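

Placing pyridin-2-yl on a saturated chain carbon bound to an amide-type nitrogen moves the number in this assay beyond the scatter, giving a 2.9-fold higher number from compound 2 to compound 3 (0.46 log units; beyond the scatter). Measured against the methyl on a carbonyl carbon, ((pyridin-2-yl)methyl)amino gives a 2.5-fold higher number from compound 1 to compound 3 (0.39 log units; beyond the scatter), whereas methylamino there stayed within the scatter, so this position does respond to what is attached. Nothing available explains the higher dose needed. Going by these compounds, whether a plain phenyl ring in place of pyridin-2-yl, or a simple ethyl group, would raise the number too remains open.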